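Compound 4: methoxy in place of cyano

The compounds below may be only part of what the source reports. "The series", "measured", "known", "first", "only" and "open" are said of these compounds alone.

Compound 1 `CCN(CC)C(=O)CN(c1ccc(C)cc1)S(=O)(=O)c1cccc(C)c1` is the starting point of the series. In a functional assay on CHO cells for inhibition of Orexin/Hypocretin receptor type 1 (Homo sapiens), read by FLIPR and calcium flux (a higher number here means a weaker inhibitor, a lower number a stronger inhibitor), compound 1 gives only a limit, > 10000 nM. Compound 2 `CCN(CC)C(=O)CN(c1ccc(C)cc1)S(=O)(=O)c1cccc(F)c1` likewise reaches only a limit of > 10000 nM in this assay. Compound 3 `CCN(CC)C(=O)CN(c1ccc(C)cc1)S(=O)(=O)c1ccc(C#N)cc1` also stops at a limit, > 10000 nM, in this assay. The steps a step that the two limits leave unreadable from compound 1 to compound 2, a step that the two limits leave unreadable from compound 1 to compound 3 and a step that the two limits leave unreadable from compound 2 to compound 3 therefore cannot be read; all three values sit at the limit of > 10000 nM in this assay, at which 3 of the 3 values shown sit. On the numbers shown, compound 3 stands nowhere better than the limit, and no ordering among the three compounds can be drawn.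

Compound 4 `CCN(CC)C(=O)CN(c1ccc(C)cc1)S(=O)(=O)c1ccc(OC)cc1` carries methoxy in place of cyano on an aromatic carbon. Among the measured compounds shown here, no measured step bears on this change in a readable way; the nearest comparisons, a step that the two limits leave unreadable from compound 1 to compound 3 and a step that the two limits leave unreadable from compound 2 to compound 3, exchange the whole group on the sulfonyl sulfur and are themselves unreadable. For the measured compounds named here, with every value so far at the limit of > 10000 nM in this assay, at which 3 of the 3 values shown sit, compound 4 is expected to remain at the limit as well, and the step that the limit leaves unreadable from compound 3 to compound 4 is an estimate with no measured anchor. For compound 4 the expected value in this assay is 20000 nM, with a range from 5000 nM to 100000 nM.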

Compound 4, half-maximal inhibitory concentration: > 10000 nM
Compound 4: no number, only a limit; the forecaster's own chance of this, stated with the estimate: 85%; the middle value is on the limit's open side.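

Compound 4 gives only a limit, so its steps from compound 1, compound 2 and compound 3 cannot be read: the limit of > 10000 nM in this assay, at which 4 of the 4 values shown sit.

The compounds shown leave open whether any group on the sulfonyl sulfur gives a measurable value in this assay.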